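The source may report more compounds than this note shows. Statements on the series, on what has been measured and on what is new or still open speak of the compounds shown alone.

Measured compounds:
Compound 1 `Cc1cccc2[nH]c(-c3n[nH]c4ncc(-c5cncc6ccccc56)cc34)nc12` gives 3090 nM in a functional assay on HeLa cells (Homo sapiens) for antiproliferative activity; on this read-out higher numbers stand for weaker inhibition and lower numbers for stronger inhibition.
Compound 2 `COCc1cccc2[nH]c(-c3n[nH]c4ncc(-c5cccnc5)cc34)nc12` gives 650 nM in this assay.
Compound 3 `COCc1cccc2[nH]c(-c3n[nH]c4ncc(-c5ccncc5)cc34)nc12` gives 3090 nM in this assay.

Compound 3 stands level with compound 1 at the digits shown, and together they carry the highest numbers of the three. Its nearest neighbour is compound 1, with no change at the digits shown, and its furthest is compound 2, which shows a lower number. Among the measured compounds shown here, the only step measured at the ring in question is a 4.8-fold higher number from compound 2 to compound 3 (0.68 log units; beyond the scatter), a modest change beyond the scatter.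

Compound 4 `COCc1cccc2[nH]c(-c3n[nH]c4ncc(-c5cncnc5)cc34)nc12` differs from compound 3 in one place: pyrimidin-5-yl in place of pyridin-4-yl on an aromatic carbon. For the measured compounds named here, no measured pair covers pyrimidin-5-yl at this position, so the expectation rests only on the step from compound 2 to compound 3. That step shows that exchanging one six-membered aromatic ring for another at this place moves this assay by a modest amount, and compound 4 is therefore expected to differ from compound 3 by a step of similar or smaller size, most likely toward a lower number, with a 2.1-fold lower number from compound 3 to compound 4 (0.31 log units; beyond the scatter) as the estimated change. Compound 4 is estimated at 1500 nM, with a range from 450 nM to 5000 nM.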

Compound 4, half-maximal inhibitory concentration: 9910 nM
Compound 4: middle estimate off by 6.6-fold (0.82 log units), on the low side; the measured number lies above the stated range.
By their numbers in this assay, from the lowest: compound 2; then compounds 1 and 3 (each within the scatter of the next); then compound 4.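

The new step, a 3.2-fold higher number from compound 3 to compound 4 (0.51 log units; beyond the scatter) in this assay, shows that this position responds to more than the swap of one pyridine isomer for another: a ring with two hetero atoms in place of one moves the number further, and upward. Read with the earlier step, the widest gap now measured at this place, a 15-fold higher number from compound 2 to compound 4 (1.18 log units; beyond the scatter), is large, and it arises between rings with the same count of heavy atoms, which differ only in their hetero atoms. Among the three compounds sharing the methoxymethyl group, the numbers rise from pyridin-3-yl through pyridin-4-yl to pyrimidin-5-yl, each step beyond the scatter, so a further ring nitrogen or a further hydrogen-bond acceptor on this ring does not by itself go with a lower number here.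

From the compounds shown here alone, it remains open where a plain phenyl ring with no ring nitrogen, or a ring carrying an amine, would fall in this order, and whether the order of the three rings holds with the methyl group of compound 1 in place of methoxymethyl. Nothing measured in this set speaks to what lies behind these differences.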